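Tolerated Concentrations of Three Compounds in MT4 Cells

The compounds below may be only part of what the source reports. "The series", "measured", "known", "first", "only" and "open" are said of these compounds alone.

- Compound 1 `CC(=O)Nc1ccc2oc(-c3ccccc3F)c(O)c(=O)c2c1`: 171000 nM
- Compound 2 `COc1ccc(-c2oc3ccc(NC(C)=O)cc3c(=O)c2OC)cc1`: 369000 nM
- Compound 3 `COc1c(-c2ccccc2F)oc2ccc(NC(C)=O)cc2c1=O`: not yet measured

In an ADME assay on MT4 cells (Homo sapiens) for cytotoxicity, read by MTT assay, with a stated time of 4 days (a lower number here means that less compound is tolerated, a higher number that more compound is tolerated), compound 2 stands highest of the two measured compounds at 369000 nM, beyond the scatter from compound 1. Compound 3 carries 2-fluorophenyl in place of 4-methoxyphenyl on an aromatic carbon, and the methoxy group of compound 2 stays. For the measured compounds named here, no measured pair isolates this change, but compound 1, which also carries 2-fluorophenyl, gives 171000 nM. A slight downward move in this assay, within the scatter, is therefore expected, giving an estimated 1.5-fold lower number from compound 2 to compound 3 (0.17 log units; within the scatter). For compound 3 the estimate is 250000 nM, with an expected range of 110000 nM to 500000 nM.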

Compound 3, half-maximal cytotoxic concentration: 180000 nM
For compound 3 the middle estimate is 1.4-fold (0.14 log units) above the measured one; measured number inside the range.
By their numbers in this assay, from the lowest: compounds 1 and 3 (each within the scatter of the next); then compound 2.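

In this assay, for the compounds shown here, 2-fluorophenyl in place of 4-methoxyphenyl on the aromatic carbon next to the ring oxygen gives a 2.1-fold lower number from compound 2 to compound 3 (0.31 log units; beyond the scatter), a modest step and the first reading that isolates this change. With 2-fluorophenyl present, methyl in place of hydrogen on the oxygen gives a 1.1-fold higher number from compound 1 to compound 3 (0.02 log units; within the scatter), so compound 1 and compound 3 cannot be told apart here. No supporting measurement bears on either step.

The compounds shown leave open whether an amine or a carboxylic acid on the phenyl ring would move the tolerated concentration. They also leave open whether the same methyl-for-hydrogen change would prove equally silent alongside 4-methoxyphenyl.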